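The compounds below may be only part of what the source reports. "The series", "measured", "known", "first", "only" and "open" are said of these compounds alone.

Measured so far:
compound 1, `O=C(c1ccncc1)N1N=C(c2cc3ccccc3o2)CC1c1ccccc1` — > 209000 nM
compound 2, `CCn1cc(C(=O)N2N=C(c3cc4ccccc4o3)CC2c2ccccc2OC)c(=O)c2ccc(C)nc21` — > 187000 nM

In an ADME assay on Vero cells (Chlorocebus sabaeus) for cytotoxicity, read by MTT assay, with a stated time of 72 h (a higher number here means a weaker inhibitor, a lower number a stronger inhibitor), compound 1 gives > 209000 nM, which is a limit of the assay and not a number. Compound 1 therefore sits at the limit of > 209000 nM in this assay, at which 1 of the 2 values shown sits. In this assay compound 2 gives > 187000 nM, again a limit rather than a measured number. Compound 2 accordingly sits at the limit of > 187000 nM in this assay, at which 1 of the 2 values shown sits, so on the numbers shown it stands at the top of the tested range, alongside compound 1, with neither compound giving a finite value and no step between measured compounds available to draw on.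

Compound 3, `CCn1cc(C(=O)N2N=C(c3cc4ccccc4o3)CC2c2ccccc2)c(=O)c2ccc(C)nc21`, differs from compound 2 in one place: hydrogen in place of methoxy on an aromatic carbon. The methoxy leaves and a hydrogen atom enters on an aromatic carbon of the six-membered aromatic ring of carbon only, so that 2-methoxyphenyl becomes phenyl.

Since both measured compounds reach only a limit in this assay, the step that the limit leaves unreadable from compound 2 to compound 3 is expected to be none beyond the scatter. Compound 3 is thus expected to give about 200000 nM, within 100000 nM to 400000 nM, and most probably to be reported again only as a limit.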

Compound 3, half-maximal inhibitory concentration: > 210000 nM
Compound 3 was reported as a limit (the forecaster's own chance of this, stated with the estimate: 80%); middle value at least 1.0-fold (0.02 log units) away from the limit.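

Compound 2 and compound 3 are both reported only as limits in this assay, so no step can be read for the change from 2-methoxyphenyl to phenyl. The compounds shown leave open whether any of them would give a finite value, and whether the methoxy makes any difference to it.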